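A few compounds are considered here, and "the series" means these few. Any claim that something is new, unique, unknown or untested is made for them only; others in the source may bear on it.

Measured so far in an in vitro functional assay on cells for agonist activity at Bombesin receptor subtype-3 (Homo sapiens), read by luminescence and calcium flux; on this read-out higher numbers stand for an effect only at larger amounts of compound and lower numbers for an effect already at smaller amounts: compound 1 `CCCCc1cnc(C(C)Cc2ccc(-c3ccccc3C(=O)O)cc2)[nH]1` gives 2760 nM; compound 2 `O=C(O)c1ccccc1-c1ccc(CCc2ncc(Cc3ccccc3Cl)[nH]2)cc1` gives 292 nM; compound 3 `N#Cc1ccc(Cc2cnc(CCc3ccc(-c4ccccc4C(=O)O)cc3)[nH]2)cc1` gives 5890 nM.

Compound 3 holds the highest number of the three; compound 1 is nearest and compound 2 furthest. Compound 4 `O=C(O)c1ccccc1-c1ccc(CCc2ncc(CC3CC3)[nH]2)cc1` is not yet measured. It differs from compound 3 by cyclopropyl in place of 4-cyanophenyl on a saturated chain carbon bound to an aromatic carbon. Going by the values given here, the only step at this position, a 20-fold higher number from compound 2 to compound 3 (1.30 log units; beyond the scatter), shows the group on the saturated chain carbon matters strongly, but neither it nor the values of compound 1 speak directly to a cyclopropyl here. Given that compound 1, with a butyl group, gives 2760 nM, a small aliphatic group is expected to land near that level, so a modest downward step is expected a 1.7-fold lower number from compound 3 to compound 4 (0.23 log units; within the scatter). Compound 4 is estimated at 3500 nM, range 1000 nM to 12000 nM.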

Compound 4, half-maximal effective concentration: 1000 nM
For compound 4 the middle estimate is 3.5-fold (0.54 log units) above the measured one; the measured number falls inside the stated range.
By their numbers in this assay, from the lowest: compound 2; then compound 4; then compound 1; then compound 3.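

In this assay, cyclopropyl in place of 4-cyanophenyl on a saturated chain carbon bound to an aromatic carbon gives a 5.9-fold lower number from compound 3 to compound 4 (0.77 log units; beyond the scatter) and cyclopropyl in place of 2-chlorophenyl gives a 3.4-fold higher number from compound 2 to compound 4 (0.53 log units; beyond the scatter) in the same series. The cyclopropyl compound therefore falls inside the span set by the two substituted phenyl groups. At this place, a non-aromatic ring of carbon only can thus give a lower number than one aromatic group and a higher number than another.

Still open, from the compounds shown here alone, is how unsubstituted phenyl, cyclohexyl or an amine would read at this place. Nothing available bears on the cause of either step.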